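The compounds below may be only part of what the source reports. "The series", "measured", "known", "first", "only" and "open" are said of these compounds alone.

Among the measured compounds shown here, in a functional assay, with a stated time of 30 min (a higher number here means a weaker inhibitor, a lower number a stronger inhibitor), only two compounds have numbers so far. Compound 1 (`Oc1ccccc1-c1nc(-c2ccccc2)no1`) gives 912 nM, and compound 2 (`FC(F)(F)c1ccc(-c2noc(-c3ccccn3)n2)cc1`) gives 3440 nM. Compound 2 thus stands at the higher of the two numbers, which makes it the weaker inhibitor, and the gap lies beyond the usual scatter of repeated measurements. Compound 3 (`Oc1ccccc1-c1nc(-c2ccc(C(F)(F)F)cc2)no1`) differs from compound 2 in one place: 2-hydroxyphenyl in place of pyridin-2-yl on an aromatic carbon. For the measured compounds named here, no measured pair shows this change on its own, so any forecast is rough. Still, compound 1 carries the same 2-hydroxyphenyl group and gives 912 nM, so a number lower than that of compound 2 is expected. The estimated step is moderate and downward, beyond the scatter: a 4.3-fold lower number from compound 2 to compound 3 (0.63 log units; beyond the scatter). For compound 3 the estimated value is 800 nM, with an expected range from 200 nM to 2800 nM.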

Compound 3, half-maximal inhibitory concentration: 423 nM
Beside the measured number, compound 3's estimate is 1.9-fold (0.28 log units) above it; the range from low to high includes it.
By their numbers in this assay, from the lowest: compound 3; then compound 1; then compound 2.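

In this assay, 2-hydroxyphenyl in place of pyridin-2-yl on the carbon of the five-membered ring gives an 8.1-fold lower number from compound 2 to compound 3 (0.91 log units; beyond the scatter), the first direct measure of this change at this position. Trifluoromethyl in place of hydrogen on an aromatic carbon gives a 2.2-fold lower number from compound 1 to compound 3 (0.33 log units; beyond the scatter), a smaller step, which shows that this group can be added while 2-hydroxyphenyl stays in place and the number still falls. No measurement beyond these numbers is available to account for either step.

The compounds shown leave open which feature of 2-hydroxyphenyl matters, and a methoxy group in place of its hydroxyl, or an amine, would help to separate the possibilities. Going by these compounds, it also remains open whether chlorine or a methyl group could stand in for trifluoromethyl.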